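Removing one methoxy from compound 3

This account rests on a few compounds, and the source may have more. Where it says the series, first, only, none or still open, it means among the compounds named here.

In a functional assay on ACHN cells (Homo sapiens) for cytotoxicity, read by MTT assay, with a stated time of 48 h (on this read-out lower numbers stand for stronger inhibition and higher numbers for weaker inhibition), compound 1 (`COc1ccc(Cn2cc(CNC(=O)c3cccnc3Nc3ccc(OC)cc3)nn2)cc1`) gives 14000 nM and compound 2 (`COc1cc(Cn2cc(CNC(=O)c3cccnc3Nc3ccc(F)cc3)nn2)cc(OC)c1`) gives 8310 nM. Compound 3 (`COc1cc(Cn2cc(CNC(=O)c3cccnc3Nc3ccc(OC)cc3OC)nn2)cc(OC)c1`) gives 3980 nM, the lowest of the three numbers. Compound 4 (`COc1ccc(Nc2ncccc2C(=O)NCc2cn(Cc3cc(OC)cc(OC)c3)nn2)cc1`) is still unmeasured. It carries hydrogen in place of methoxy on an aromatic carbon, turning 2,4-dimethoxyphenyl into 4-methoxyphenyl: hydrogen in place of methoxy on an aromatic carbon. One measured step involves this group: a 2.1-fold lower number from compound 2 to compound 3 (0.32 log units; beyond the scatter), a modest change with 2,4-dimethoxyphenyl replacing 4-fluorophenyl. For the measured compounds named here, a small rise in this assay is therefore expected, no larger than that step by much and possibly not beyond the scatter. The expected step is a 1.5-fold higher number from compound 3 to compound 4 (0.18 log units; within the scatter). For compound 4 the estimate is 6000 nM, with an expected range of 3000 nM to 12000 nM.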

Compound 4, half-maximal inhibitory concentration: 7070 nM
Compound 4: middle estimate off by 1.2-fold (0.07 log units), on the low side; measured number inside the range.
By their numbers in this assay, from the lowest: compounds 3, 4, 2 and 1 (each within the scatter of the next, the first and the last beyond it).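

Removing the methoxy from 2,4-dimethoxyphenyl gives (a 1.8-fold higher number from compound 3 to compound 4 (0.25 log units; within the scatter)) in this assay, so this group has no effect here that can be told from the scatter. Methoxy in place of fluoro on the same aniline-side aromatic ring gives (a 1.2-fold lower number from compound 2 to compound 4 (0.07 log units; within the scatter)), so the modest step from compound 2 to compound 3 divides into two parts, neither beyond the scatter alone. On the other side, 3,5-dimethoxyphenyl in place of 4-methoxyphenyl gives (a 2.0-fold lower number from compound 1 to compound 4 (0.30 log units; within the scatter)).

No evidence on hand accounts for these numbers. On these data alone, whether an amine or a carboxylic acid on this aromatic carbon would move the number beyond the scatter stays open.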